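Swapping the sulfonyl chain end: butyl to methoxyethyl

A few compounds are considered here, and "the series" means these few. Any claim that something is new, unique, unknown or untested is made for them only; others in the source may bear on it.

Compound 1 `CC(=O)N1CCN(c2ccc(OCC3CCN(C(=O)OC(C)C)CC3)cn2)CC1`: in a functional assay on CHO-K1 cells for agonist activity at Glucose-dependent insulinotropic receptor (Homo sapiens), read by a luciferase reporter, with a stated time of 5 h (a lower number here means that less compound is needed, a higher number that more compound is needed for the effect), compound 1 reaches only the assay limit > 10000 nM.
Compound 2 `CCCCS(=O)(=O)N1CCN(c2ccc(OCC3CCN(C(=O)OC(C)C)CC3)cn2)CC1`: in this assay compound 2 gives 100 nM.

For the measured compounds named here, compound 2 holds the only number here; the other value is a limit, as the limit of > 10000 nM in this assay, at which 1 of the 2 values shown sits, notes. Compound 3 `COCCS(=O)(=O)N1CCN(c2ccc(OCC3CCN(C(=O)OC(C)C)CC3)cn2)CC1` differs from compound 2 by methoxy in place of ethyl on a saturated chain carbon, two bonds along the chain from a sulfonyl sulfur. Going by the values given here, the single measured step, an at least 100-fold lower number from compound 1 to compound 2 (2.00 log units; beyond the scatter), changed the whole group on that ring nitrogen, not the chain beyond the sulfonyl, so it offers no direct guide. A step within the scatter, a 2.0-fold higher number from compound 2 to compound 3 (0.30 log units; within the scatter), is expected. Compound 3 is therefore estimated at 200 nM, between 50 nM and 1000 nM.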

Compound 3, half-maximal effective concentration: 300 nM
Compound 3: middle estimate off by 1.5-fold (0.18 log units), on the low side; the range from low to high includes it.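

In this assay the far end of the sulfonyl chain counts in its own right: methoxy in place of ethyl alone gives a 3.0-fold higher number from compound 2 to compound 3 (0.48 log units; beyond the scatter) and so a modest loss. The (2-methoxyethyl)sulfonyl group still stands well clear of acetyl, with an at least 33-fold lower number from compound 1 to compound 3 (1.52 log units; beyond the scatter) for the whole exchange on the ring nitrogen. That step starts from a limit of the assay, not a number: the limit of > 10000 nM in this assay, at which 1 of the 3 values shown sits.

As far as these compounds go, whether a methyl on the sulfonyl, a longer chain or a chain ending in an amine would give a lower number than compound 2 stays open.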